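Swapping a five-membered ring for a six-membered one

The compounds below may be only part of what the source reports. "The series", "measured", "known", "first", "only" and "open" are said of these compounds alone.

Of the compounds shown here, three have been tested in an assay on isolated protein for inhibition of DNA topoisomerase 1 (Homo sapiens), with a stated time of 30 min, tested at 100 uM; on this read-out higher numbers stand for a stronger effect at the one concentration tested and lower numbers for a weaker effect. Compound 1 `Oc1cccc(-c2cc(-c3ccccc3)cc(-c3cccc(O)c3)n2)c1` gives 67.2%. Compound 2 `Oc1ccc(-c2cc(-c3ccccc3)cc(-c3cccs3)n2)cc1` gives 4.9%. Compound 3 `Oc1cccc(-c2cc(-c3ccccc3)nc(-c3cccs3)c2)c1` gives 9.1%. On these numbers compound 3 stands second highest of three: its nearest neighbour is compound 2, a number lower by an amount within the usual scatter, and its furthest is compound 1, a number higher by an amount beyond the scatter.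

Compound 4 `Oc1cccc(-c2cc(-c3ccccc3)nc(-c3ccccn3)c2)c1` has not yet been measured. It differs from compound 3 in one place: pyridin-2-yl in place of thiophen-2-yl on an aromatic carbon. For the measured compounds named here, no pair of measured compounds shows this particular change, so its effect has to be guessed rather than read off. Compound 3 and compound 2 both carry a thiophen-2-yl group and both sit low, while compound 1, with two 3-hydroxyphenyl groups, sits high. The expected step of a number 5.9 percentage points higher from compound 3 to compound 4 (within the scatter) is therefore small, without a clear direction and likely within the scatter. Compound 4 is expected to give about 15% in this assay, in a range from 0% to 40%.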

Compound 4, a percentage reported as inhibition, at one concentration (the size of the read-out at that concentration, not a potency): 10.8%
Beside the measured number, compound 4's estimate is 4.2 percentage points above it; low and high end bracket the measured number.
By their numbers in this assay, from the lowest: compounds 2, 3 and 4 (each within the scatter of the next); then compound 1.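

In this assay, placing pyridin-2-yl instead of thiophen-2-yl on the aromatic carbon next to the ring nitrogen gives a number 1.7 percentage points higher from compound 3 to compound 4 (within the scatter) and so makes no readable difference. For the compounds shown here, this is the only measured pair that differs at this position alone, and it shows that a six-membered aromatic ring with nitrogen as its hetero atom can replace a five-membered one with sulfur without moving the read-out beyond the usual scatter. Nothing measured here bears on the reason for this result.

Still open, as far as these compounds go, is whether any group at this position can move the number beyond the scatter, for example a dimethylamino group, a carboxylic acid or a short alkyl chain. From the compounds shown here alone, it is also open whether the same ring exchange would behave alike on a different core.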